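The source may report more compounds than this note shows. Statements on the series, on what has been measured and on what is new or still open speak of the compounds shown alone.

Working notes on the series

Compound 1 `N#CNC(=N)NCCCCn1nc(-c2ccccc2)ccc1=O` gives 77.2 mg/kg in a functional assay on the whole organism (stomach) with Rattus norvegicus as the target (a lower number here means that less compound is needed, a higher number that more compound is needed for the effect), and holds the lowest of the two numbers shown, with compound 3 nearest to it. Compound 3 `CC/N=C(/NC#N)NCCCn1nc(-c2ccccc2)ccc1=O` gives 78.3 mg/kg in this assay, and the step of a 1.0-fold higher number from compound 1 to compound 3 (0.01 log units; within the scatter) is flat. Compound 2 `C/N=C(/NC#N)NCCCn1nc(-c2ccccc2)ccc1=O` reaches only a limit in this assay, > 100 mg/kg. The step of an at least 1.2-fold higher number from compound 1 to compound 2 (0.11 log units; that floor lies within the scatter) is therefore only a floor, as is an at least 1.2-fold lower number from compound 2 to compound 3 (0.10 log units; that floor lies within the scatter); one of the three values sits at the limit of > 100 mg/kg in this assay, at which 1 of the 3 values shown sits.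

Compound 4 `CC(C)(C)/N=C(\S)NCCCCn1nc(-c2ccccc2)ccc1=O` differs from compound 1 by a group of 7 heavy atoms (5 carbon, 1 nitrogen, 1 sulfur; no ring) in place of a group of 5 heavy atoms (2 carbon, 3 nitrogen; no ring), on an amine nitrogen. Going by the values given here, no measured step touches the amine nitrogen itself; the steps from compound 1 to compounds 3 and 2 exchange whole groups on the chain carbon, one flat and one a floor, so they bear only loosely on this change. From them, no step beyond the scatter is expected for compound 4, with the open possibility of a limit as seen for compound 2. Compound 4 is estimated at 80 mg/kg in this assay, between 30 mg/kg and 160 mg/kg, meaning an expected step of a 1.0-fold higher number from compound 1 to compound 4 (0.02 log units; within the scatter).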

Compound 4, dose for half-maximal effect: > 100 mg/kg
Compound 4 ended at the assay's limit (the forecaster's own chance of this, stated with the estimate: 30%); at least 1.2-fold (0.09 log units) between middle value and limit.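

In this assay compound 4 gives > 100 mg/kg, which is a limit and not a number. The step of an at least 1.2-fold higher number from compound 1 to compound 4 (0.11 log units; that floor lies within the scatter) is therefore only a floor: the group of 7 heavy atoms (5 carbon, 1 nitrogen, 1 sulfur) in place of the group of 5 heavy atoms (2 carbon, 3 nitrogen), on an amine nitrogen, gives no reading of how far the number moves. This is the first change shown at this position, and the limit no longer rests on compound 2 alone: the limit of > 100 mg/kg in this assay, at which 2 of the 4 values shown sit.

Where compound 4 would stand beyond the limit remains open. The entering group changes in several respects at once, so the sulfur cannot be separated from the rest of it; a urea with oxygen in place of the sulfur would bear directly on this.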